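A few compounds are considered here, and "the series" means these few. Any claim that something is new, unique, unknown or untested is made for them only; others in the source may bear on it.

Working notes on the series

Of the compounds shown here, three on the shared core have been measured in an assay on mitochondria from L6 cells (Rattus norvegicus) for activation, with a stated time of 90 min; a lower number here means that less compound is needed, a higher number that more compound is needed for the effect. Compound 1, `Fc1cc(F)c(Nc2nc3nonc3nc2Nc2c(F)cc(F)cc2F)c(F)c1`, gives 1100 nM. Compound 2, `Fc1cc(I)ccc1Nc1nc2nonc2nc1Nc1ccc(I)cc1F`, gives 8800 nM. Compound 3, `Fc1ccccc1Nc1nc2nonc2nc1Nc1cccc(F)c1F`, gives 500 nM and stands lowest of the three numbers; the nearest is compound 1, whose gap to compound 3 lies beyond the scatter, and the furthest is compound 2, whose gap to compound 3 lies well beyond the scatter. Going by the values given here, no pair among the measured compounds differs in a single place, so no measured single step exists to lean on.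

The next compound, compound 4, is `CCOc1ccccc1Nc1nc2nonc2nc1Nc1ccccc1F`. It differs from compound 3 in one place: 2-ethoxyphenyl in place of 2,3-difluorophenyl on a nitrogen on an aromatic ring. Nothing measured in the series bears on this particular change, since every measured compound carries halogen-substituted phenyl groups on both sides of the core and none carries an ethoxy group. The step from compound 3 to compound 4 in this assay is therefore expected to be modest and is estimated as a 2.0-fold higher number from compound 3 to compound 4 (0.30 log units; within the scatter), with a wide range around it rather than a firm direction. Compound 4 is expected to give about 1000 nM in this assay, within an estimated range from 300 nM to 4000 nM.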

Compound 4, half-maximal effective concentration: 5600 nM
Beside the measured number, compound 4's estimate is 5.6-fold (0.75 log units) below it; the whole stated range lies below it.
By their numbers in this assay, from the lowest: compound 3; then compound 1; then compounds 4 and 2 (each within the scatter of the next).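

Going by these compounds alone, putting 2-ethoxyphenyl in place of 2,3-difluorophenyl on a nitrogen on an aromatic ring gives an 11-fold higher number from compound 3 to compound 4 (1.05 log units; beyond the scatter) in this assay and is the first step that can be read in a single place. It shows that the number is sensitive to the group at this position, and that this change goes towards more compound being needed, by a large step rather than one lost in the scatter. The data in hand offer nothing that bears on why the number moves this far, so the step stands as an observation only.

The change removes two fluorines and brings in an ethoxy group in one move, going from 8 heavy atoms to 9 and from 0 hydrogen-bond acceptors to 1, so the share of each part in the step cannot be separated from this pair alone. On these data alone, whether a methoxy group, a longer alkoxy chain, a hydroxyl group or an amine in the same place would shift the number as far, or in the same direction, stays open.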